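Half-life of three measured amides and one untested diketopiperazine

The source may report more compounds than this note shows. Statements on the series, on what has been measured and on what is new or still open speak of the compounds shown alone.

Measured compounds and their values:
compound 1 `CCCC[C@H]1CN(c2cccc(C)c2C)C(=O)CN1Cc1cncn1Cc1ccc(C#N)cc1` with 0.6 h
compound 2 `CCCC[C@H]1CN(c2cccc(C)c2C)C(=O)C(=O)N1Cc1cncn1Cc1ccc(C#N)cc1` with 0.9 h
compound 3 `Cc1cccc(N2CCN(Cc3cncn3Cc3ccc(C#N)cc3)CC2=O)c1C` with 0.5 h

In an ADME assay for pharmacokinetics (a higher number here means that the compound lasts longer, a lower number that the compound disappears faster), compound 1 gives 0.6 h. Compound 2 gives 0.9 h and compound 3 gives 0.5 h in this assay; all three numbers lie within the scatter of one another, so no order among them can be read. The difference between the core of compound 1 and the core of compound 2 is not broken down here.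

Compound 4 `Cc1cccc(N2CCN(Cc3cncn3Cc3ccc(C#N)cc3)C(=O)C2=O)c1C` has not yet been measured in this assay. It differs from compound 2 by hydrogen in place of butyl on a saturated ring carbon. The same change has been made once already, from compound 1 to compound 3, where it is hydrogen in place of butyl on a saturated ring carbon and gave a 1.2-fold lower number from compound 1 to compound 3 (0.08 log units; within the scatter).

Among the compounds with values here, for compound 4 a step of about a 1.2-fold lower number from compound 2 to compound 4 (0.08 log units; within the scatter) is expected, resting on the one earlier step of a 1.2-fold lower number from compound 1 to compound 3 (0.08 log units; within the scatter), which stayed within the scatter. The estimate for compound 4 in this assay is therefore 0.75 h, with a likely range from 0.4 h to 1.4 h.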

Compound 4, half-life in the ADME assay: 1 h
Estimate against measurement, compound 4: 1.3-fold (0.12 log units) below; measured number inside the range.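

In the ADME assay, hydrogen in place of butyl on a saturated ring carbon gave a 1.1-fold higher number from compound 2 to compound 4 (0.05 log units; within the scatter), and this step agrees with the one on the other core: the same change on two cores in the ADME assay, a 1.2-fold lower number (0.08 log units; within the scatter) from compound 1 to compound 3 and a 1.1-fold higher number (0.05 log units; within the scatter) from compound 2 to compound 4, 1.3-fold (0.12 log units) apart, within the scatter of two such steps. The change therefore carried from one core to the other in these two pairs, in the sense that neither pair shows a readable shift in half-life, but two steps within the scatter show no effect that could be transferred and say nothing of cores beyond these. In a physicochemical assay for lipophilicity (a higher number here means a more lipophilic compound, a lower number a more polar compound), compound 2 gives 3.3 and compound 4 gives 1.11. The same change on the core of compound 2 did shift the physicochemical assay well beyond the scatter, without a readable shift in half-life in that pair: the measured partition coefficient of compound 2, 3.3, and of compound 4, 1.11, a number 2.19 log units lower (beyond the scatter).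

The compounds shown leave open whether any group on that saturated ring carbon would move the half-life beyond the scatter. A shorter chain such as ethyl, a longer chain, an amine or a carboxylic acid in the place of butyl could test this on both cores.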